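A few compounds are considered here, and "the series" means these few. Any claim that something is new, unique, unknown or untested is made for them only; others in the source may bear on it.

Four compounds share one core and differ in two places. Compound 1, `COc1ccc(-c2cc(C(=O)Nc3nc4ccc(Cl)cc4s3)nc3cc(-c4ccccc4)nn23)cc1`, is the starting point; in a functional assay on ACHN cells (Homo sapiens) for cytotoxicity, read by MTT assay, with a stated time of 48 h (a higher number here means a weaker inhibitor, a lower number a stronger inhibitor), compound 1 gives 7240 nM. Compound 2, `COc1ccc(-c2cc(C(=O)Nc3nc4ccc(Cl)cc4s3)nc3cc(-c4ccccc4)nn23)cc1OC`, differs from compound 1 by one change, (methoxy in place of hydrogen on an aromatic carbon). This change made the step of a 1.1-fold higher number from compound 1 to compound 2 (0.03 log units; within the scatter), so in this assay compound 2 gives 7760 nM, a number that cannot be told apart from that of compound 1.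

Compound 3, `COc1ccc(-c2cc(C(=O)Nc3nc4ccccc4s3)nc3cc(-c4ccccc4)nn23)cc1`, carries a different core. How the core of compound 3 differs from the core of compound 1 is hydrogen in place of chloro on an aromatic carbon. That change made the step of a 4.3-fold lower number from compound 1 to compound 3 (0.63 log units; beyond the scatter), and in this assay compound 3 gives 1690 nM, the lowest number among the three measured compounds.

Compound 4, `COc1ccc(-c2cc(C(=O)Nc3nc4ccccc4s3)nc3cc(-c4ccccc4)nn23)cc1OC`, has not yet been measured. Compound 4 differs from compound 3 by methoxy in place of hydrogen on an aromatic carbon. The place of this change is the same, word for word, as the place of the change from compound 1 to compound 2, so it is the same change, made on the other core. Among the compounds with values here, because the earlier change made only the step of a 1.1-fold higher number from compound 1 to compound 2 (0.03 log units; within the scatter), a step within the scatter, the step from compound 3 to compound 4 is also expected to be small, and the estimate for it is a 1.1-fold higher number from compound 3 to compound 4 (0.03 log units; within the scatter). On that basis compound 4 is expected to give about 1800 nM in this assay, most likely between 800 nM and 4000 nM.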

Compound 4, half-maximal inhibitory concentration: 7940 nM
The estimate for compound 4 lay 4.4-fold (0.64 log units) below the measured number; the measured number lies above the stated range.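

The methoxy change gave a 4.7-fold higher number from compound 3 to compound 4 (0.67 log units; beyond the scatter) in this assay, so the near absence of an effect on the core of compound 1 did not carry over to the core of compound 3: the same change on two cores in this assay, a 1.1-fold higher number (0.03 log units; within the scatter) from compound 1 to compound 2 and a 4.7-fold higher number (0.67 log units; beyond the scatter) from compound 3 to compound 4, 4.4-fold (0.64 log units) apart, beyond the scatter of two such steps

Read the other way round, hydrogen in place of chloro gave a 1.0-fold higher number from compound 2 to compound 4 (0.01 log units; within the scatter), so this change also depends on what else the molecule carries: the same change on two cores in this assay, a 4.3-fold lower number (0.63 log units; beyond the scatter) from compound 1 to compound 3 and a 1.0-fold higher number (0.01 log units; within the scatter) from compound 2 to compound 4, 4.4-fold (0.64 log units) apart, beyond the scatter of two such steps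

These four compounds show that the two changes do not simply add up in this series, and that a step measured on one core cannot be assumed to hold on the other, but they do not show why this happens or whether it extends to other groups, cores or cell lines.

As far as these compounds go, it remains open whether the lower number of compound 3 needs exactly the combination of a 4-methoxyphenyl group and a core without chloro, or whether other combinations would give it too. A hydroxyl group or an amine in place of the added methoxy, or fluoro or methyl in place of the chloro, would help to show how narrow that combination is.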